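The source may hold more compounds than are shown below. What is called first, only, known or untested is meant among the compounds shown, and "the series" means these compounds.

Series notes, step from compound 2 to compound 4.

Of the compounds shown here, three sharing one core have been read in a functional assay on isolated protein for inhibition of Glucose-dependent insulinotropic receptor (Rattus norvegicus), read by HTRF and cAMP accumulation; on this read-out higher numbers stand for larger maximal responses and lower numbers for smaller maximal responses. Compound 1 `Cc1nc(S(C)(=O)=O)ccc1Oc1ncnc(OC2CCN(C(=O)OC(C)(C)CF)CC2)c1F` gives 95%. Compound 2 `Cc1nc(S(C)(=O)=O)ccc1Oc1ncnc(OC2CCN(C(=O)OC3(C(F)(F)F)COC3)CC2)c1F` gives 84%. Compound 3 `Cc1nc(S(C)(=O)=O)ccc1Oc1ncnc(OC2CCN(C(=O)C3(F)CCC3)CC2)c1F` gives 91%. On these numbers compound 2 has the lowest efficacy of the three: the gap to compound 3 is a number 7 percentage points higher from compound 2 to compound 3 (within the scatter), within the scatter, while the other gap is a number 11 percentage points lower from compound 1 to compound 2 (beyond the scatter), beyond the scatter.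

Compound 4 `Cc1nc(S(C)(=O)=O)ccc1Oc1ncnc(OC2CCN(C(=O)c3nc(C(C)(C)F)no3)CC2)c1F` has not yet been measured in this assay. It differs from compound 2 by a group of 9 heavy atoms (5 carbon, 2 nitrogen, 1 oxygen, 1 fluorine; one five-membered aromatic ring with 3 hetero atoms) in place of a group of 9 heavy atoms (4 carbon, 2 oxygen, 3 fluorine; one four-membered non-aromatic ring with 1 hetero atom), on a carbonyl carbon

Within the data shown here, the step bearing most on this is the one from compound 2 to compound 3, which also replaced the group on the carbonyl carbon with a carbon-linked ring and gave a number 7 percentage points higher from compound 2 to compound 3 (within the scatter), within the scatter. The step from compound 1 to compound 3, again a change on the carbonyl carbon, gave a number 4 percentage points lower from compound 1 to compound 3 (within the scatter), also within the scatter. Among the measured compounds shown here, the only change beyond the scatter, a number 11 percentage points lower from compound 1 to compound 2 (beyond the scatter), moved between two oxygen-linked groups and does not map onto the present change. A step of about a number 5 percentage points higher from compound 2 to compound 4 (within the scatter) is therefore expected in this assay, small and upward if anything, possibly none beyond the scatter. Compound 4 is estimated at 89%, with a range from 78% to 98%.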

Compound 4, largest response reached (reported as efficacy), in percent of the reference or control that the assay uses: 84%
Estimate against measurement, compound 4: 5 percentage points above, and the stated range covers the measured number.
By their numbers in this assay, from the lowest: compounds 2, 4, 3 and 1 (each within the scatter of the next, the first and the last beyond it).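

In this assay the carbonyl carbon whose other neighbour is the amide-type nitrogen in a ring now carries a five-membered aromatic ring with 3 hetero atoms, and setting this group in place of (3-(trifluoromethyl)oxetan-3-yl)oxy gives no change at the digits printed from compound 2 to compound 4 (within the scatter), so two groups with the same heavy-atom count but different rings and different linking atoms read alike at this position. The same change of group gives a number 7 percentage points lower from compound 3 to compound 4 (within the scatter) and a number 11 percentage points lower from compound 1 to compound 4 (beyond the scatter), which shows that a step beyond the scatter from compound 1 is not confined to compound 2, although compound 3 goes against any general pattern by staying within the scatter of compound 1. Nothing measured here offers an explanation for these steps.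

On these data alone, what a phenyl ring, a nitrile or a carboxylic acid would give on this carbonyl carbon remains open. The compounds shown also leave open whether the aromatic ring itself or its fluorinated substituent sets the reading of compound 4 in this assay, as no compound here carries one without the other.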